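Carbamoylmethyl on the methylated nitrogen of compound 3

The source may report more compounds than this note shows. Statements on the series, on what has been measured and on what is new or still open speak of the compounds shown alone.

Among the compounds with values here, compound 3 `COc1cc2[nH]c(=O)n(C)c2cc1NS(=O)(=O)c1cccc(Cl)c1Cl` stands at the top of the numbers so far: in a functional assay on CHO cells for antagonist activity at C-C chemokine receptor type 4 (Homo sapiens), read by radioligand binding and GTPgammaS binding (on this read-out lower numbers stand for stronger inhibition and higher numbers for weaker inhibition), compound 3 gives 20000 nM, while the parent compound 1 `COc1cc2[nH]c(=O)[nH]c2cc1NS(=O)(=O)c1cccc(Cl)c1Cl` gives 316 nM and compound 2 `COc1cc2c(cc1NS(=O)(=O)c1cccc(Cl)c1Cl)[nH]c(=O)n2CC(N)=O` gives 457 nM. The step of a 63-fold higher number from compound 1 to compound 3 (1.80 log units; beyond the scatter) is the only large one; the step of a 1.4-fold higher number from compound 1 to compound 2 (0.16 log units; within the scatter) is not. Compound 4 `COc1cc2[nH]c(=O)n(CC(N)=O)c2cc1NS(=O)(=O)c1cccc(Cl)c1Cl` differs from compound 3 by carbamoyl in place of hydrogen on a saturated chain carbon bound to an aromatic nitrogen. Within the data shown here, two measured steps bear on it: the methyl on an aromatic nitrogen that produced a 63-fold higher number from compound 1 to compound 3 (1.80 log units; beyond the scatter), and the carbamoylmethyl on an aromatic nitrogen that produced a 1.4-fold higher number from compound 1 to compound 2 (0.16 log units; within the scatter). Among the measured compounds shown here, compound 2 carries its carbamoylmethyl on a different aromatic nitrogen than compound 4 does, so no measured pair shows whether a carbamoylmethyl recovers what the methyl of compound 3 lost. A partial recovery in this assay seems the more likely outcome, so a moderate step of a 2.5-fold lower number from compound 3 to compound 4 (0.40 log units; beyond the scatter) is expected. Compound 4 is estimated at 8000 nM, with a range from 2000 nM to 30000 nM.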

Compound 4, half-maximal inhibitory concentration in the C-C chemokine receptor type 4 assay: > 31600 nM
Compound 4: a limit, no number; the forecaster's own chance of this, stated with the estimate: 15%; middle value at least 3.9-fold (0.59 log units) away from the limit.
By their numbers in the C-C chemokine receptor type 4 assay, from the lowest: compounds 1 and 2 (each within the scatter of the next); then compound 3. At a limit, above all of these: compound 4.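

In the C-C chemokine receptor type 4 assay the carbamoylmethyl on this aromatic nitrogen gives an at least 100-fold higher number from compound 1 to compound 4 (2.00 log units; beyond the scatter), whereas on the other aromatic nitrogen it gives a 1.4-fold higher number from compound 1 to compound 2 (0.16 log units; within the scatter), so the two nitrogens of the core of compound 1 do not respond alike to the same group. The result for compound 4 is a limit of the assay, not a number: the limit of > 31600 nM in the C-C chemokine receptor type 4 assay, at which 1 of the 4 values shown sits. Going from methyl to carbamoylmethyl brings no recovery of inhibition (an at least 1.5-fold higher number from compound 3 to compound 4 (0.19 log units; that floor lies within the scatter)), even though lipophilicity falls: the measured distribution coefficient of compound 3, 3.7, and of compound 4, 2.4, a number 1.30 log units lower (beyond the scatter). In a physicochemical assay for lipophilicity, at pH 7.4 (a higher number here means a more lipophilic compound, a lower number a more polar compound), compound 3 gives 3.7 and compound 4 gives 2.4 on the same read-out.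

The compounds shown do not tell whether this nitrogen must keep its hydrogen or whether some other substituent could be accepted there. An amine or a carboxylic acid at the end of the same chain, or a smaller group such as ethyl, would test how general the loss is.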